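The source may hold more compounds than are shown below. What is called first, only, known or untested is meant among the compounds shown, and "the series" means these compounds.

In an ADME assay on the whole organism (plasma, Rattus norvegicus) for protein binding, using cassette dosing, at a dose of 1 mg/kg (on this read-out lower numbers stand for a smaller free fraction and higher numbers for a larger free fraction), compound 1 `C[C@@H](Cn1c(=O)[nH]/c(=N\c2ccc(Oc3nccs3)cc2)n(Cc2ccc(Cl)cc2)c1=O)C(=O)O` gives 0.006, compound 2 `Cc1ccc(Cn2c(=O)n(C[C@H](C)C(=O)O)c(=O)[nH]/c2=N\c2ccc(OC(C)C)c(Cl)c2)cc1` gives 0.014, and compound 3 `CC(C)Oc1ccc(Nc2nc(=O)n(CCO)c(=O)n2Cc2ccc(Cl)cc2)cc1Cl` gives 0.001. Compound 3 therefore stands lowest of the three, and its gaps to both others lie beyond the usual scatter of repeated measurements. Compound 4 `CC(C)Oc1ccc(Nc2nc(=O)n(CCCO)c(=O)n2Cc2ccc(Cl)cc2)cc1Cl` differs from compound 3 by one small change on the side chain, 2-hydroxyethyl to 3-hydroxypropyl: hydroxymethyl in place of hydroxy on a saturated chain carbon, two bonds along the chain from an aromatic nitrogen. Among the measured compounds shown here, no two measured compounds show this change, so the expectation rests on its small size alone, and no shift beyond the scatter is expected in this assay. The estimate means an expected no change at the digits printed from compound 3 to compound 4 (within the scatter). For compound 4 the estimated value is 0.001, with an expected range of 0.0004 to 0.003.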

Compound 4, unbound fraction: 0.003
The estimate for compound 4 lay 3.0-fold (0.48 log units) below the measured number; the measured number falls inside the stated range.
By their numbers in this assay, from the lowest: compound 3; then compounds 4 and 1 (each within the scatter of the next); then compound 2.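

Going from 2-hydroxyethyl to 3-hydroxypropyl gives a 3.0-fold higher number from compound 3 to compound 4 (0.48 log units; beyond the scatter) in this assay. This shows that the free fraction responds at this position to a small change, hydroxymethyl in place of hydroxy, which keeps the hydrogen-bond donor and acceptor counts the same. The earlier compounds could not show this, as no two of them formed a one-place pair, and nothing available explains the step. One step cannot say whether the trend continues along the chain. A longer chain, such as 4-hydroxybutyl, or an amine in place of the hydroxy, would test that.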